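A few compounds are considered here, and "the series" means these few. Any claim that something is new, unique, unknown or untested is made for them only; others in the source may bear on it.

Compound 1 `O=C(Nc1ccc(Oc2ccnc3[nH]ccc23)cc1)c1cn(-c2ccc(Cl)cc2)c2ccccc2c1=O` gave 1590 nM in a functional assay on MCF7 cells (Homo sapiens) for inhibition, read by MTT assay, with a stated time of 72 h; a higher number here means a weaker inhibitor, a lower number a stronger inhibitor. Compound 2 `O=C(Nc1ccc(Oc2ccnc3[nH]ccc23)cc1)c1cn(-c2ccc(C(F)(F)F)cc2Cl)c2ccccc2c1=O` gave 3570 nM in this assay. Compound 3 `Cn1ccc2c(Oc3ccc(NC(=O)c4cn(-c5ccc(Cl)cc5)c5ccccc5c4=O)cc3F)ccnc21` gave 2120 nM in this assay.

Among these three numbers compound 3 stands second highest, yet its value lies within the usual scatter of both compound 1 and compound 2, so no order among them can be claimed. Compound 4 `Cn1ccc2c(Oc3ccc(NC(=O)c4cn(-c5ccc(C(F)(F)F)cc5Cl)c5ccccc5c4=O)cc3F)ccnc21` is not yet measured. It differs from compound 3 in one place: 2-chloro-4-(trifluoromethyl)phenyl in place of 4-chlorophenyl on an aromatic nitrogen. That same exchange appears once among the measured compounds, where it gave a 2.2-fold higher number from compound 1 to compound 2 (0.35 log units; beyond the scatter). On that single precedent a step of similar size and direction is expected here, so compound 4 is estimated at 4700 nM, between 2400 nM and 9500 nM, which means a 2.2-fold higher number from compound 3 to compound 4 (0.35 log units; beyond the scatter).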

Compound 4, half-maximal inhibitory concentration: 190 nM
Beside the measured number, compound 4's estimate is 25-fold (1.39 log units) above it; measured number below the stated range.
By their numbers in this assay, from the lowest: compound 4; then compounds 1, 3 and 2 (each within the scatter of the next, the first and the last beyond it).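

On the core of compound 3, 2-chloro-4-(trifluoromethyl)phenyl in place of 4-chlorophenyl gives an 11-fold lower number from compound 3 to compound 4 (1.05 log units; beyond the scatter) and so runs against the earlier step in this assay on the core of compound 1. What this exchange does at this position therefore cannot be told from the group alone, since the outcome depends on the core that carries it: the same change on two cores in this assay, a 2.2-fold higher number (0.35 log units; beyond the scatter) from compound 1 to compound 2 and an 11-fold lower number (1.05 log units; beyond the scatter) from compound 3 to compound 4, 25-fold (1.40 log units) apart, beyond the scatter of two such steps

The two cores differ by a methyl group and a fluorine, and the compounds shown leave open which of the two turns the step around. Also open, going by these compounds, is how a phenyl carrying only trifluoromethyl, or a nitrile in its place, would behave on either core.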